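A few compounds are considered here, and "the series" means these few. Any claim that something is new, unique, unknown or untested is made for them only; others in the source may bear on it.

Measured compounds in a functional assay on REH cells (Homo sapiens) for cytotoxicity, read by MTT assay, with a stated time of 72 h; on this read-out lower numbers stand for stronger inhibition and higher numbers for weaker inhibition:
compound 1 `N#Cc1ccc(NC(=O)CN2C(=O)/C(=C/c3ccc(-c4ccc(Cl)cc4)o3)SC2=S)cc1` gives 90000 nM
compound 2 `COc1ccc(CNC(=O)CN2C(=O)/C(=C/c3ccc(-c4ccc(Cl)cc4)o3)SC2=S)cc1` gives 44000 nM
compound 3 `Cc1ccc(CNC(=O)CN2C(=O)/C(=C/c3ccc(-c4ccc(Cl)cc4)o3)SC2=S)cc1` gives 45000 nM

Compound 3 sits second highest of the three numbers; its nearest neighbour is compound 2 (a 1.0-fold higher number from compound 2 to compound 3 (0.01 log units; within the scatter)) and its furthest is compound 1 (a 2.0-fold lower number from compound 1 to compound 3 (0.30 log units; within the scatter)), both within the scatter. The unmeasured compound 4 `O=C(CN1C(=O)/C(=C/c2ccc(-c3ccc(Cl)cc3)o2)SC1=S)Nc1nnn[nH]1` differs from compound 3 by 1H-tetrazol-5-yl in place of 4-methylbenzyl on an amide-type nitrogen. For the measured compounds named here, the only steps that bear on this position are a 2.0-fold lower number from compound 1 to compound 3 (0.30 log units; within the scatter) and a 2.0-fold lower number from compound 1 to compound 2 (0.31 log units; beyond the scatter), both small, which suggests that exchanging the group on the amide nitrogen has so far moved this assay little. A small step, if any, is therefore expected for a 1.6-fold higher number from compound 3 to compound 4 (0.19 log units; within the scatter), with a weak lean toward a higher number as seen for the directly attached aromatic group of compound 1 (90000 nM). Compound 4 is estimated at 70000 nM, within 25000 nM to 200000 nM.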

Compound 4, half-maximal inhibitory concentration: 50000 nM
For compound 4 the middle estimate is 1.4-fold (0.15 log units) above the measured one; the measured number falls inside the stated range.
By their numbers in this assay, from the lowest: compounds 2, 3, 4 and 1 (each within the scatter of the next, the first and the last beyond it).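

In this assay the 1H-tetrazol-5-yl group on the amide-type nitrogen gives a 1.1-fold higher number from compound 3 to compound 4 (0.05 log units; within the scatter) and a 1.1-fold higher number from compound 2 to compound 4 (0.06 log units; within the scatter). Against the directly attached 4-cyanophenyl group it gives a 1.8-fold lower number from compound 1 to compound 4 (0.26 log units; within the scatter), so the amide-type nitrogen now carries a five-membered aromatic ring with 4 hetero atoms in place of a six-membered carbon ring without a step that leaves the scatter. Nothing measured here offers a reason for this flat response.

On these data alone, whether an amine, a carboxylic acid or a longer alkyl chain on this nitrogen would move the number stays open. So does whether changes to the shared core outside this position would do so.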